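This account rests on a few compounds, and the source may have more. Where it says the series, first, only, none or still open, it means among the compounds named here.

Measured compounds:
Compound 1, `CN1CCC[C@@H]1Cn1nc(CCc2ccccc2)c2ccccc2c1=O`, gives 200 nM in an assay for binding affinity to Alpha-1B adrenergic receptor (Homo sapiens); on this read-out higher numbers stand for weaker inhibition and lower numbers for stronger inhibition.
Compound 2, `COc1ccc(Cc2nn(C[C@H]3CCCN3C)c(=O)c3ccccc23)cc1OC`, reaches only the limit > 1990 nM in this assay, a limit of the method and not a number.
Compound 3, `CCCCCc1nn(C[C@H]2CCCN2C)c(=O)c2ccccc12`, gives 1000 nM in this assay.

Among the two numbers obtained, compound 3 stands at the higher one, with compound 1 as its nearest neighbour; the only other result, for compound 2, is a limit, as the limit of > 1990 nM in this assay, at which 1 of the 3 values shown sits, records. Compound 4, `COc1cccc(Cc2nn(C[C@H]3CCCN3C)c(=O)c3ccccc23)c1`, has not yet been measured in this assay. It differs from compound 3 by 3-methoxyphenyl in place of butyl on a saturated chain carbon bound to an aromatic carbon.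

Within the data shown here, one measured step bears on this change. The step of a 5.0-fold higher number from compound 1 to compound 3 (0.70 log units; beyond the scatter) shows that replacing an aromatic ring by an alkyl chain at a chain carbon raised the number by a modest margin. The move from compound 3 to compound 4 runs the other way, from an alkyl chain back to an aromatic ring, now carrying a methoxy group, and so a somewhat lower number would be expected. Compound 2, however, with its dimethoxybenzyl group, sits at the limit, which tempers that expectation. On balance compound 4 is expected to lie near compound 3 or modestly below it, with the step of a 1.4-fold lower number from compound 3 to compound 4 (0.15 log units; within the scatter). The estimated value for compound 4 in this assay is 700 nM, within a range of 200 nM to 2500 nM.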

Compound 4, inhibition constant: > 1990 nM
Compound 4 was reported as a limit; the forecaster's own chance of this, stated with the estimate: 25%; at least 2.8-fold (0.45 log units) between middle value and limit.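

In this assay, the change at this position reads as an at least 1.9-fold higher number from compound 3 to compound 4 (0.29 log units; that floor lies within the scatter), so the data do not show that 3-methoxyphenyl in place of butyl brings the number down, as the step from compound 1 to compound 3 alone might have suggested. The comparison with the lowest number is clearer, at an at least 9.9-fold higher number from compound 1 to compound 4 (0.99 log units; beyond the scatter), which shows that an aromatic ring on the chain does not by itself carry the lower number of compound 1, and that the 3-methoxybenzyl group of compound 4 does not match the phenethyl-type chain there. Compound 2 and compound 4, the two compounds with methoxy-bearing benzyl groups, both end at a limit of the assay, so the step between them cannot be read: the limit of > 1990 nM in this assay, at which 2 of the 4 values shown sit.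

On these data alone, it remains open how an unsubstituted benzyl group or a longer phenylpropyl chain would stand in this assay, and so whether the methoxy groups or the length of the chain matter more. As far as these compounds go, it is equally open whether a hydroxyl group or a fluorine atom on the ring in place of methoxy would bring a number clear of the limit.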